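Aryl substituent swap and tolerated concentration in liver cells

The source may hold more compounds than are shown below. What is called first, only, known or untested is meant among the compounds shown, and "the series" means these compounds.

Measured compounds:
- compound 1, `Cc1ccccc1-c1nn(C(C)C)cc1CNCCN1CCN(C)CC1`, > 20000 nM 
- compound 2, `Cc1ccccc1-c1nn(-c2ccc(Br)cc2)cc1CNCCN1CCN(C)CC1`, 9600 nM 

In an ADME assay on Huh-7 cells (Homo sapiens) for cytotoxicity (a lower number here means that less compound is tolerated, a higher number that more compound is tolerated), compound 1 gives only a limit, > 20000 nM, and the limit of > 20000 nM in this assay, at which 1 of the 2 values shown sits, sets that bound. Among the compounds with values here, compound 2 is the only compound with a number in this assay, at 9600 nM. Within the data shown here, the one measured step, an at least 2.0-fold lower number from compound 1 to compound 2 (0.31 log units; beyond the scatter), is the sole guide to how this assay answers changes on the aromatic nitrogen. Compound 3, `CSc1ccc(-n2cc(CNCCN3CCN(C)CC3)c(-c3ccccc3C)n2)cc1`, differs from compound 2 by methylsulfanyl in place of bromo on an aromatic carbon. This change is smaller than the measured one, which exchanged isopropyl for a whole 4-bromophenyl, and it keeps the aryl group in place, so no step beyond the scatter is expected. Compound 3 is therefore estimated at 9000 nM in this assay, between 4000 nM and 20000 nM. The expected step of a 1.1-fold lower number from compound 2 to compound 3 (0.03 log units; within the scatter) stays within the usual scatter.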

Compound 3, half-maximal cytotoxic concentration: 17000 nM
The estimate for compound 3 lay 1.9-fold (0.28 log units) below the measured number; the range from low to high includes it.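

At the aromatic carbon that carries bromo in compound 2, methylsulfanyl gives in this assay a 1.8-fold higher number from compound 2 to compound 3 (0.25 log units; within the scatter), so this exchange on the aryl group does not separate the two compounds. The replacement of isopropyl on the aromatic nitrogen now has a second reading, an at least 1.1-fold lower number from compound 1 to compound 3 (0.07 log units; that floor lies within the scatter), and unlike the step with the 4-bromophenyl group, this one does not clear the scatter. Compound 1 gives only a limit, so the full size of this step stays unknown: the limit of > 20000 nM in this assay, at which 1 of the 3 values shown sits.

The compounds shown leave open how an amine or a carboxylic acid at this aromatic carbon would read in this assay. They also leave open how a longer chain on the aromatic nitrogen would compare with isopropyl and the two aryl groups.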